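A few compounds are considered here, and "the series" means these few. Any claim that something is new, unique, unknown or untested is made for them only; others in the source may bear on it.

Measured compounds:

Compound 1 `CC1CCN(c2nc(C(F)(F)F)ccc2CNC(=O)C(c2ccc(NS(C)(=O)=O)c(F)c2)C2CCCCC2)CC1`: in an assay on CHO cells for antagonist activity at transient receptor potential cation channel subfamily V member 1 (Homo sapiens), read by FLIPR (a higher number here means a weaker inhibitor, a lower number a stronger inhibitor), compound 1 gives 31.1 nM.
Compound 2 `Cc1ccccc1C(C(=O)NCc1ccc(C(F)(F)F)nc1N1CCC(C)CC1)c1ccc(NS(C)(=O)=O)c(F)c1`: in this assay compound 2 gives 42.9 nM.

Among the compounds with values here, compound 2 has the higher of the two numbers so far, but the only step that reaches it, a 1.4-fold higher number from compound 1 to compound 2 (0.14 log units; within the scatter), is within the scatter, so the two compounds are not separated by the data.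

Compound 3 `Cc1ccc(C(C(=O)NCc2ccc(C(F)(F)F)nc2N2CCC(C)CC2)c2ccc(NS(C)(=O)=O)c(F)c2)cc1` is not yet measured. It differs from compound 2 only in this: 4-methylphenyl in place of 2-methylphenyl on a saturated chain carbon bound to an aromatic carbon and a carbonyl carbon. The change keeps the same atoms and moves the methyl on the aryl ring from one ring position to another.

Within the data shown here, no measured step bears directly on this change. Among the measured compounds shown here, the single step available, from compound 1 to compound 2, swaps a cyclohexyl for a 2-methylphenyl at the same saturated chain carbon and stays within the scatter, so the series gives no sign that this position is sensitive to what sits there. The same outcome is therefore expected for compound 3: a step within the scatter, with no preferred direction, a 1.0-fold higher number from compound 2 to compound 3 (0.00 log units; within the scatter).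

The estimate for compound 3 in this assay is 43 nM, with a range from 14 nM to 130 nM.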

Compound 3, inhibition constant: 1.1 nM
Beside the measured number, compound 3's estimate is 39-fold (1.59 log units) above it; the measured number lies below the stated range.
By their numbers in this assay, from the lowest: compound 3; then compounds 1 and 2 (each within the scatter of the next).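

In this assay the saturated chain carbon bound to an aromatic carbon and a carbonyl carbon proves highly sensitive to the placement of a single methyl: 4-methylphenyl in place of 2-methylphenyl gives a 39-fold lower number from compound 2 to compound 3 (1.59 log units; beyond the scatter) with the same atoms in both compounds. The earlier swap, a 1.4-fold higher number from compound 1 to compound 2 (0.14 log units; within the scatter) and so within the scatter, gave no sign of this, and the new result shows that the aryl group's substitution pattern can matter far more here than the choice between cyclohexyl and 2-methylphenyl; 4-methylphenyl in place of cyclohexyl likewise gives a 28-fold lower number from compound 1 to compound 3 (1.45 log units; beyond the scatter) and leaves compound 3 as the most potent of the three compounds. Nothing available here accounts for the size of this shift.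

The compounds shown leave open whether the result is specific to 4-methylphenyl or would extend to other groups at this carbon, such as unsubstituted phenyl, 3-methylphenyl, 4-ethylphenyl, 4-chlorophenyl or 4-methoxyphenyl. They also leave open whether 2-methylphenyl lowers the potency that unsubstituted phenyl would give or 4-methylphenyl raises it, and whether the same methyl shift would hold on a different shared core.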